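Swapping the aryl group of compound 3

The source may hold more compounds than are shown below. What is called first, only, known or untested is meant among the compounds shown, and "the series" means these compounds.

Measured in an ADME assay on MT2 cells (Homo sapiens) for cytotoxicity, read by XTT assay, with a stated time of 4 days; a lower number here means that less compound is tolerated, a higher number that more compound is tolerated:
Compound 1 `Cc1nc(C(NC(=O)C(=O)Nc2ccc(Cl)cc2)C2CCNCC2)sc1CCO` gives > 78500 nM, a limit
Compound 2 `Cc1ccc(NC(=O)C(=O)NC(c2nc(C)c(CCO)s2)C2CCCCN2)c(F)c1` gives > 78800 nM, a limit
Compound 3 `Cc1ccc(NC(=O)C(=O)NC(c2nc(C)c(CO)s2)C2CCCCN2)c(F)c1` gives > 109000 nM, a limit

Compound 3 therefore stands at a limit, as do both other compounds, and none of the three has a readable number. Compound 4 `Cc1nc(C(NC(=O)C(=O)Nc2ccc(F)cc2)C2CCCCN2)sc1CO` differs from compound 3 at one place: 4-fluorophenyl in place of 2-fluoro-4-methylphenyl on an amide-type nitrogen. Here 4-fluorophenyl replaces 2-fluoro-4-methylphenyl on an amide-type nitrogen. Within the data shown here, the only measured step, a step that the two limits leave unreadable from compound 2 to compound 3, concerns hydroxy in place of hydroxymethyl, not this group, and it offers no size to carry over. With compound 3 at > 109000 nM as a limit, no step beyond the scatter is expected in this assay. The expected step is a step that the limit leaves unreadable from compound 3 to compound 4, an estimate that stays within the scatter. Compound 4 is expected at 110000 nM, with an estimated range from 60000 nM to 200000 nM, and may well be reported only as a limit.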

Compound 4, half-maximal cytotoxic concentration: > 113000 nM
Compound 4: only a limit was reported (the forecaster's own chance of this, stated with the estimate: 85%); at least 1.0-fold (0.01 log units) between middle value and limit.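

Compound 3 gives > 109000 nM, a limit. Compound 4 gives > 113000 nM, also a limit, so no step can be read between them. The compounds shown leave open whether 4-fluorophenyl in place of 2-fluoro-4-methylphenyl shifts the half-maximal cytotoxic concentration at all.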